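Flipping one stereocentre in a compound at the limit

The compounds below may be only part of what the source reports. "The series", "measured", "known", "first", "only" and "open" are said of these compounds alone.

In a functional assay on B16 cells (Mus musculus) for cytotoxicity, read by MTT assay (a lower number here means a stronger inhibitor, a higher number a weaker inhibitor), compound 1 (`CC(=O)O[C@@H]1OC(=O)[C@](C)(C(C)=O)[C@@H]1C`) gives 4000 nM and compound 2 (`CC(=O)[C@@]1(C)C(=O)O[C@@H](OC(=O)C(C)(C)C)[C@H]1C`) gives 2000 nM on the same core. Swapping methyl for tert-butyl on the carbonyl carbon yields a 2.0-fold lower number from compound 1 to compound 2 (0.30 log units; within the scatter) here.

With ethyl on the oxygen, compound 3 (`CCO[C@@H]1OC(=O)[C@](C)(C(C)=O)[C@@H]1C`) reads > 50000 nM as a limit of the assay and not as a number. Compound 3 therefore sits at the limit of > 50000 nM in this assay, at which 1 of the 3 values shown sits, and has no exact place on the scale.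

Compound 4 (`CCO[C@@H]1OC(=O)[C@@](C)(C(C)=O)[C@@H]1C`) shows the two compounds have the same atoms and bonds and differ only in configuration as drawn: 1 of 3 stereo elements differ; a stereocentre at a saturated ring carbon is drawn S in compound 3 and R in compound 4 and a stereocentre at a saturated ring carbon is drawn S in compound 3 and R in compound 4. Within the data shown here, no measured step changes configuration alone, so none sizes this change directly. The two large steps, an at least 12-fold higher number from compound 1 to compound 3 (1.09 log units; beyond the scatter) and an at least 25-fold higher number from compound 2 to compound 3 (1.39 log units; beyond the scatter), both came with a change of the group on that oxygen, and compound 4 keeps the ethyl of compound 3.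

The expectation is therefore no step beyond the scatter, with no direction favoured, an estimated step that the limit leaves unreadable from compound 3 to compound 4 in this assay and a real uncertainty. For compound 4 the estimate is 60000 nM with an expected range from 20000 nM to 150000 nM and quite possibly only a limit again.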

Compound 4, half-maximal inhibitory concentration: > 50000 nM
Compound 4 gave a limit, no number; the forecaster's own chance of this, stated with the estimate: 75%; the middle value lies beyond the limit too.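

In this assay, no step can be read between compound 3 and compound 4, because each gives a limit of the assay and not a number: the limit of > 50000 nM in this assay, at which 2 of the 4 values shown sit.

The compounds shown leave open whether flipping this one stereocentre moves the reading at all, and in which direction, with ethyl on the oxygen or with the groups of compound 1 and compound 2.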